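A few compounds are considered here, and "the series" means these few. Any claim that something is new, unique, unknown or untested is made for them only; others in the source may bear on it.

Measured so far:
- compound 1, `COc1ccc(-c2cc(C(C)=O)c3[nH]c(-c4ccccc4)cc3c2)cc1`: 88.8%
- compound 2, `CC(=O)c1cc(-c2ccc(F)cc2)cc2cc(-c3ccc(F)cc3)[nH]c12`: 93.2%

In a functional assay on MCF7 cells (Homo sapiens) for cytotoxicity, read by MTT assay, with a stated time of 2 days, tested at 1 uM (a lower number here means a stronger effect, a higher number a weaker effect of the compound at the concentration tested), compound 2 gives 93.2%, the higher of the two numbers measured, but the number for compound 1 lies only a few points away, a gap that sits within the usual scatter, so the two cannot be told apart. Both compounds leave most of the cells alive at this concentration.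

Compound 3, `COc1ccc(-c2cc(C(C)=O)c3[nH]c(-c4ccc(F)cc4)cc3c2)cc1`, has not yet been measured. It differs from compound 2 in one place: methoxy in place of fluoro on an aromatic carbon. Compound 3 thus carries the 4-methoxyphenyl seen in compound 1 and the 4-fluorophenyl seen in compound 2, one on each side of the shared core.

Since compound 1 and compound 2 sit within the scatter of each other, no step beyond the scatter is expected for this exchange; the estimated step of a number 3.2 percentage points lower from compound 2 to compound 3 (within the scatter) is small. For compound 3 a value of 90% is estimated in this assay, expected between 78% and 100%.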

Compound 3, a percentage reported as activity, at one concentration (the size of the read-out at that concentration, not a potency): 69.7%
Beside the measured number, compound 3's estimate is 20.3 percentage points above it; the whole stated range lies above it.
By their numbers in this assay, from the lowest: compound 3; then compounds 1 and 2 (each within the scatter of the next).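

In this assay methoxy in place of fluoro on an aromatic carbon is not a silent exchange, since it gives a number 23.5 percentage points lower from compound 2 to compound 3 (beyond the scatter). Fluoro in place of hydrogen on an aromatic carbon also matters, with a number 19.1 percentage points lower from compound 1 to compound 3 (beyond the scatter), so compound 3, which carries both the 4-methoxyphenyl and the 4-fluorophenyl, shows the strongest effect of the three at the concentration tested. Compound 1 and compound 2 differ in two places at once, so neither single exchange could be read from that pair.

No measurement shown here explains why either exchange lowers the number. On these data alone, it remains open whether an amine, a hydroxyl or a longer alkoxy chain in place of the methoxy would go further, and whether the same exchanges would act alike on another core.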